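The source may report more compounds than this note shows. Statements on the series, on what has been measured and on what is new or still open speak of the compounds shown alone.

Compound 1, `COc1ccc(CCC(=O)NC(CCN(C)C)c2ccc(Cl)cc2)cc1`: 101%
Compound 2, `CN(C)CCC(NC(=O)CCc1ccccc1)c1ccc(Cl)cc1`: 139%

Of the compounds shown here, two have been measured. In a functional assay on NIH3T3 cells for agonist activity at Urotensin-2 receptor (Homo sapiens), with a stated time of 5 days (a lower number here means a smaller maximal response, a higher number a larger maximal response), compound 1 gives 101%, the lower of the two numbers. Compound 2 gives 139% in this assay, and the step of a number 38 percentage points higher from compound 1 to compound 2 (beyond the scatter) arises from hydrogen in place of methoxy on an aromatic carbon, on the ring remote from the amine-bearing chain.

Compound 3, `COc1ccc(CCC(=O)NC(CCN(C)C)c2ccc(C)cc2)cc1`, is not yet measured. It differs from compound 1 by methyl in place of chloro on an aromatic carbon. Among the compounds with values here, no measured step touches this position: the only step known concerns the methoxy group on the other aromatic ring, and it says nothing about an exchange of the chloro group. The large size of that step shows, however, that a single substituent change can move the maximal response in this assay well beyond the scatter, so the uncertainty for compound 3 is wide.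

Lacking a bearing step, the expectation for compound 3 is a response near that of compound 1, with the step of a number 4 percentage points higher from compound 1 to compound 3 (within the scatter) expected to stay within the scatter. Compound 3 is therefore estimated at 105% in this assay, with a range from 80% to 135%.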

Compound 3, largest response reached (reported as efficacy), in percent of the reference or control that the assay uses: 67%
The estimate for compound 3 lay 38 percentage points above the measured number; measured number outside the range, below it.
By their numbers in this assay, from the lowest: compound 3; then compound 1; then compound 2.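

In this assay, within the data shown here, the place para to a large group proves to be sensitive, something the earlier compounds could not show: methyl in place of chloro gives a number 34 percentage points lower from compound 1 to compound 3 (beyond the scatter). The maximal response therefore shifts with a single exchange on either aromatic ring, and the two known steps are both large but run in opposite directions, since the exchange of methoxy for hydrogen gives a number 38 percentage points higher from compound 1 to compound 2 (beyond the scatter). Chloro and methyl match in heavy-atom count, and neither adds a hydrogen-bond donor or acceptor, so these counts do not separate compound 1 from compound 3, and no evidence at hand accounts for the difference.

The compounds shown leave open how a fluoro, bromo or trifluoromethyl group at this place would compare with chloro and methyl, and whether the response follows any order across such groups. They also leave open whether removing the methoxy group would raise the response in the 4-methylphenyl series as it does in the 4-chlorophenyl series.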